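Cytotoxicity Across a Benzylpiperazine Series: From Sulfone to Chloropyridine

The compounds below may be only part of what the source reports. "The series", "measured", "known", "first", "only" and "open" are said of these compounds alone.

Compound 1 `CC(=O)N1CCC(C(=O)N(CCCN2CCN(Cc3ccc(C(F)(F)F)cc3)CC2)c2ccc(C)c(Cl)c2)CC1` in an ADME assay (Homo sapiens) for cytotoxicity (a higher number here means that more compound is tolerated, a lower number that less compound is tolerated), gives 30500 nM. Compound 2 `CC(=O)N1CCC(C(=O)N(CCCN2CCN(Cc3ccc(S(C)(=O)=O)cc3)CC2)c2ccc(C)c(Cl)c2)CC1` is recorded only as the limit > 49200 nM in this assay. The step of an at least 1.6-fold higher number from compound 1 to compound 2 (0.20 log units; that floor lies within the scatter) is thus bounded by the limit of > 49200 nM in this assay, at which 1 of the 2 values shown sits. Compound 3 `CC(=O)N1CCC(C(=O)N(CCCN2CCN(Cc3ccc(Cl)nc3)CC2)c2ccc(C)c(Cl)c2)CC1` differs from compound 2 by 6-chloropyridin-3-yl in place of 4-(methylsulfonyl)phenyl on a saturated chain carbon bound to an amine nitrogen in a ring. Among the measured compounds shown here, the only measured step touching this position, from compound 1 to compound 2, is small and within the scatter, so no step beyond the scatter is expected in this assay. Compound 3 is therefore estimated at 35000 nM, between 15000 nM and 70000 nM, which corresponds to an expected step of an at least 1.4-fold lower number from compound 2 to compound 3 (0.14 log units; that floor lies within the scatter).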

Compound 3, half-maximal cytotoxic concentration: > 53100 nM
Compound 3: a limit, no number; the forecaster's own chance of this, stated with the estimate: 30%; middle value at least 1.5-fold (0.18 log units) from the limit.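

In this assay compound 3 is recorded only as a limit: the limit of > 53100 nM in this assay, at which 1 of the 3 values shown sits. At this position on a saturated chain carbon bound to an amine nitrogen in a ring, 6-chloropyridin-3-yl is thus a second replacement for 4-(trifluoromethyl)phenyl that gives a limit rather than a number, with an at least 1.7-fold higher number from compound 1 to compound 3 (0.24 log units; that floor lies within the scatter). The step between the two limits cannot be read, so 6-chloropyridin-3-yl and 4-(methylsulfonyl)phenyl cannot be ranked here.

The compounds shown leave open where the true values of compound 2 and compound 3 lie. They also leave open whether a 4-aminophenyl or 4-carboxyphenyl group at this place would give a readable number.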